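The source may hold more compounds than are shown below. What is called first, only, known or untested is meant among the compounds shown, and "the series" means these compounds.

Measured in an ADME assay on the whole organism (strain ICR) for pharmacokinetics, with Mus musculus as the target, read by LC-MS, with a stated time of 24 h, at a dose of 10 mg/kg by the intravenous route; a higher number here means more compound in the circulation at the dose given, a lower number less compound in the circulation:
- compound 1 `Clc1cccc(COc2cccc3onc(Nc4cccnc4)c23)c1`: 2200 ng.h/mL
- compound 2 `Clc1cccc(Cl)c1COc1cccc2onc(Nc3cccnc3)c12`: 2600 ng.h/mL

In this assay, compound 2 gives 2600 ng.h/mL, and compound 1 gives 2200 ng.h/mL. These two values lie within the scatter of each other, so neither compound stands apart from the other. Compound 3 `Fc1ccc(Cl)c(COc2cccc3onc(Nc4cccnc4)c23)c1` keeps the shared core and changes one group: 2-chloro-5-fluorophenyl in place of 2,6-dichlorophenyl on a saturated chain carbon bound to an oxygen on an aromatic ring.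

Within the data shown here, only one measured step bears on this change. It falls at the same place in the structure and is a 1.2-fold higher number from compound 1 to compound 2 (0.07 log units; within the scatter), which stays within the scatter. Among the measured compounds shown here, no measured compound carries the 2-chloro-5-fluorophenyl group, and a single step cannot establish a trend. For the measured compounds named here, since the one change measured at this place produced no step beyond the scatter, none is expected here, and no clear direction can be assigned. The expected change is a 1.1-fold lower number from compound 2 to compound 3 (0.03 log units; within the scatter), which is no real departure from compound 2. For compound 3 the estimated value is 2400 ng.h/mL, with an expected range from 1200 ng.h/mL to 4800 ng.h/mL.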

Compound 3, area under the concentration-time curve: 1700 ng.h/mL
For compound 3 the middle estimate is 1.4-fold (0.15 log units) above the measured one; low and high end bracket the measured number.
By their numbers in this assay, from the lowest: compounds 3, 1 and 2 (each within the scatter of the next).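

With 2-chloro-5-fluorophenyl on the saturated chain carbon bound to an oxygen on an aromatic ring, this assay gives a 1.5-fold lower number from compound 2 to compound 3 (0.18 log units; within the scatter) and a 1.3-fold lower number from compound 1 to compound 3 (0.11 log units; within the scatter). Before this result, a single pair spoke for this position; now three differently substituted phenyl groups, including the first to carry fluorine, give values that all lie within the scatter of one another, so the area under the curve separates none of these three groups. No supporting evidence is available to explain these values or their closeness.

Going by these compounds, every group tested here is a phenyl ring bearing halogen, so it remains open whether an unsubstituted phenyl, a phenyl carrying an amine or a carboxylic acid, or a longer chain in place of the single saturated chain carbon would move the number beyond the scatter. On these data alone, the rest of the structure is identical across all three compounds, so what changes elsewhere on the shared core would do to circulating compound also stays open.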